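The compounds below may be only part of what the source reports. "The series", "measured", "known", "first", "only" and "open" are said of these compounds alone.

Compound 3 `Cc1cc(Nc2nc(Nc3ccc(C(=O)NC4CC(C)(C)N([O])C(C)(C)C4)cc3)ncc2[N+](=O)[O-])n[nH]1` gives 15300 nM in a functional assay on A549 cells (Homo sapiens) for antiproliferative activity, read by MTT assay, with a stated time of 48 h (a higher number here means a weaker inhibitor, a lower number a stronger inhibitor), the highest of the three numbers available. Compound 1 `CC1(C)CC(NC(=O)c2ccc(Nc3ncc([N+](=O)[O-])c(N4CCN(c5ccc(F)cc5)CC4)n3)cc2)CC(C)(C)N1[O]` gives 10300 nM in this assay, within the scatter of compound 3, while compound 2 `Cc1cc(Nc2nc(Nc3ccc(C(=O)NC4CC(C)(C)N([O])C(C)(C)C4)cc3)ncc2[N+](=O)[O-])no1` gives 1140 nM. Among the measured compounds shown here, the one single-point step on record is a 13-fold higher number from compound 2 to compound 3 (1.13 log units; beyond the scatter), which shows that exchanging the five-membered heteroaryl on the aromatic amine nitrogen can shift the number by a large amount.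

Compound 4 `CCOC(=O)Cc1csc(Nc2nc(Nc3ccc(C(=O)NC4CC(C)(C)N([O])C(C)(C)C4)cc3)ncc2[N+](=O)[O-])n1` has not been measured. It differs from compound 3 by 4-((ethoxycarbonyl)methyl)-1,3-thiazol-2-yl in place of 5-methyl-1H-pyrazol-3-yl on a nitrogen on an aromatic ring. For the measured compounds named here, no measured pair covers this exact exchange; the step from compound 2 to compound 3 is the only one touching the same place, and it was large. The direction cannot be read from the data; the size suggests a step of comparable magnitude is possible. Compound 4 is therefore expected to be estimated at 6000 nM, between 1200 nM and 30000 nM, meaning an expected step of a 2.6-fold lower number from compound 3 to compound 4 (0.41 log units; beyond the scatter).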

Compound 4, half-maximal inhibitory concentration: 1040 nM
For compound 4 the middle estimate is 5.8-fold (0.76 log units) above the measured one; the whole stated range lies above it.
By their numbers in this assay, from the lowest: compounds 4 and 2 (each within the scatter of the next); then compounds 1 and 3 (each within the scatter of the next).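

At this place, on a nitrogen on an aromatic ring, this assay now records a second large step, a 15-fold lower number from compound 3 to compound 4 (1.17 log units; beyond the scatter), so 5-methyl-1H-pyrazol-3-yl now stands apart from two other groups rather than one. The other new step, a 1.1-fold lower number from compound 2 to compound 4 (0.04 log units; within the scatter), stays within the scatter, which shows that two different five-membered rings, one carrying 4-((ethoxycarbonyl)methyl) and the other 5-methyl, can give matching numbers here. Nothing available gives a reason for either step.

The compounds shown leave open how much of the thiazole result belongs to the 1,3-thiazol-2-yl ring and how much to its ethoxycarbonylmethyl chain, a question that a plain methyl group or a carboxylic acid at the end of that chain would address. They also leave open whether a methyl group on the ring nitrogen of the pyrazole would change the number for compound 3.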